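Naphthyl-pyridine series: acrylamide and acid analogs

The source may report more compounds than this note shows. Statements on the series, on what has been measured and on what is new or still open speak of the compounds shown alone.

Measured so far:
- compound 1 `COC1CN(C(=O)/C=C/c2ccncc2-c2ccc3ccccc3c2)C1`: 42.8 nM
- compound 2 `O=C(O)CCc1ccncc1-c1ccc2ccccc2c1`: 50.5 nM
- compound 3 `CNC(=O)COc1ccncc1-c1ccc2ccccc2c1`: "not determined" (no result reported)

Among the compounds with values here, compound 3 stands without a number: in an assay on a protein complex for inhibition of CDK8/Cyclin C (Homo sapiens), with a stated time of 1 h (on this read-out higher numbers stand for weaker inhibition and lower numbers for stronger inhibition), compound 3 is recorded as "not determined" (no result reported), so no step from it can be sized. The two neighbours on the same core give the scale. In this assay, within the data shown here, compound 1 gives 42.8 nM and compound 2 gives 50.5 nM; these two values lie within the usual scatter of each other, so the series so far is flat at that level.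

Compound 4 `O=C(/C=C/c1ccncc1-c1ccc2ccccc2c1)NC1CC1` is the next member. Relative to compound 3 the change is 2-(cyclopropylcarbamoyl)ethenyl in place of (methylcarbamoyl)methoxy on an aromatic carbon. Compound 4 carries the same ethenyl-carboxamide arm as compound 1, with a different amide substituent, so the nearest reference is compound 1 at 42.8 nM rather than compound 3. Among the measured compounds shown here, with no measured step to read against, no shift beyond the scatter is expected in this assay; the value of compound 4 is expected to sit near those of compound 1 and compound 2. Compound 4 is estimated at 40 nM, with a plausible range from 15 nM to 120 nM.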

Compound 4, half-maximal inhibitory concentration: 40.1 nM
For compound 4 the middle estimate is 1.0-fold (0.00 log units) below the measured one; measured number inside the range.
By their numbers in this assay, from the lowest: compounds 4, 1 and 2 (each within the scatter of the next).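

In this assay the exchange of 3-methoxyazetidin-1-yl for cyclopropylamino on the carbonyl carbon reads as a 1.1-fold lower number from compound 1 to compound 4 (0.03 log units; within the scatter) and leaves these two amide substituents unseparated on the shared core. The exchange of 2-carboxyethyl for 2-(cyclopropylcarbamoyl)ethenyl on the aromatic carbon reads as a 1.3-fold lower number from compound 2 to compound 4 (0.10 log units; within the scatter) and so also separates nothing, which extends the flat level of the series to a third measured compound. The data on hand offer no explanation for why these groups read alike.

The steps from compound 3 cannot be read, so the (methylcarbamoyl)methoxy arm has no place in this comparison. Going by these compounds, whether a primary amine at the end of the arm, or a longer chain on the amide nitrogen, would move the number beyond the scatter remains open.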